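The source may hold more compounds than are shown below. What is called first, only, known or untested is meant among the compounds shown, and "the series" means these compounds.

The measured compounds so far:
Compound 1, `O=c1[nH]c(-c2cccc3ccccc23)nc2ccc(N3CCCCC3)cc12`: in a functional assay on T47D cells (Homo sapiens) for cytotoxicity, read by MTT assay, with a stated time of 2 days (a lower number here means a stronger inhibitor, a higher number a weaker inhibitor), compound 1 gives > 50000 nM, which is a limit of the assay, not a number.
Compound 2, `Cc1ccc2nc(-c3cccc(OC(F)(F)F)c3)[nH]c(=O)c2c1`: in this assay compound 2 gives > 50000 nM, likewise a limit of the assay.

Among the compounds with values here, compound 2 therefore stands where every value so far stands, namely at the limit of > 50000 nM in this assay, at which 2 of the 2 values shown sit. No step between two measured compounds has been shown, so there is nothing yet that tells how much any single change shifts the reading in this assay.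

Compound 3, `Cc1ccc2nc(-c3cccc(F)c3)[nH]c(=O)c2c1`, differs from compound 2 in one place: fluoro in place of trifluoromethoxy on an aromatic carbon. With both measured compounds resting at the same limit, the expectation for compound 3 is a step of no size beyond the scatter, a number no higher from compound 2 to compound 3 (the limit leaves the size open), with the reading most likely again a limit. The estimate for compound 3 in this assay is 50000 nM, within a range from 20000 nM to 100000 nM.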

Compound 3, half-maximal inhibitory concentration: > 50000 nM
Compound 3 gave a limit, no number; the forecaster's own chance of this, stated with the estimate: 85%; the middle value sits exactly at the limit.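

Within the data shown here, compound 2 and compound 3 both rest at a limit of the assay rather than at a number, so putting fluoro in place of trifluoromethoxy gives no step that can be read. The compounds shown leave open whether any single change moves the reading in this assay, and all of them stand at one place: the limit of > 50000 nM in this assay, at which 3 of the 3 values shown sit.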